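This account rests on a few compounds, and the source may have more. Where it says the series, first, only, none or still open, it means among the compounds named here.

Compound 1 `COc1cc(O)cc(CCCCCCC/C=C\CCCCCCCc2cc(OC)cc(OC)c2)c1`: 9.8 ug/mL
Compound 2 `Oc1cc(O)cc(CCCCCCCCC/C=C\CCCCCCCCCc2cc(O)cc(O)c2)c1`: 10.2 ug/mL
Compound 3 `Oc1cc(O)cc(CCCCCCC/C=C\CCCCCCCCCc2cc(O)cc(O)c2)c1`: 9.4 ug/mL

In a functional assay on A2780 cells (Homo sapiens) for cytotoxicity (on this read-out higher numbers stand for weaker inhibition and lower numbers for stronger inhibition), compound 3 gives 9.4 ug/mL, which lies within the scatter of the other two values, so the three compounds cannot be ranked. The next compound is compound 4 `COc1cc(O)cc(CCCCCCC/C=C\CCCCCCCc2cc(O)cc(O)c2)c1`, and the change is 3-hydroxy-5-methoxyphenyl in place of 2-(3,5-dihydroxyphenyl)ethyl on a saturated chain carbon, seven bonds along the chain from a double-bonded chain carbon.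

One measured step acts at the same place: a 1.1-fold lower number from compound 2 to compound 3 (0.04 log units; within the scatter). It alters only the group on that chain carbon, and it stays within the scatter. Compound 1, which also carries a 3-hydroxy-5-methoxyphenyl group, gives 9.8 ug/mL, a value indistinguishable from that of compound 3. Among the measured compounds shown here, no measured step isolates the exchange of a hydroxy group for a methoxy group, so that part of the change remains untested. On this evidence, no step beyond the scatter is expected in this assay, and the expected change is a 1.1-fold higher number from compound 3 to compound 4 (0.03 log units; within the scatter). The estimated value for compound 4 is 10 ug/mL, with an expected range of 6 ug/mL to 16 ug/mL.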

Compound 4, half-maximal inhibitory concentration: 10 ug/mL
Beside the measured number, compound 4's estimate shows no gap at the digits printed; the range from low to high includes it.
By their numbers in this assay, from the lowest: compounds 3, 1, 4 and 2 (each within the scatter of the next).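

In this assay, the step that brings in 3-hydroxy-5-methoxyphenyl at this place stays within the scatter (a 1.1-fold higher number from compound 3 to compound 4 (0.03 log units; within the scatter)), and so does the step that puts 3,5-dihydroxyphenyl in place of 3,5-dimethoxyphenyl on the same saturated chain carbon (a 1.0-fold higher number from compound 1 to compound 4 (0.01 log units; within the scatter)). Among the compounds shown here, the second step isolates an exchange of methoxy groups for hydroxy groups, which the earlier compounds left untested, and at this end of the chain that exchange does not separate compound 1 from compound 4. No evidence at hand accounts for this flat picture.

The compounds shown leave open whether any group on this chain carbon moves the number beyond the scatter. An amine or a carboxylic acid in place of the hydroxy groups, or a chain without the double bond, would test this.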